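Compound 1 and a trifluoromethyl swap

The source may report more compounds than this note shows. Statements on the series, on what has been measured and on what is new or still open speak of the compounds shown alone.

Values in a functional assay on SGC-7901 cells (Homo sapiens) for inhibition, read by MTT assay, with a stated time of 72 h (a higher number here means a weaker inhibitor, a lower number a stronger inhibitor), follow
- compound 1 `Cc1ccc(N2CCCC2)c(C(=O)Nc2ccc(CNC(=O)OCc3cccnc3)cc2)c1` gives 65300 nM
- compound 2 `O=C(NCc1ccc(NC(=O)c2cc(F)ccc2N2CCCC2)cc1)OCc1cccnc1` gives 44800 nM
- compound 3 `Cc1cccc(C(=O)Nc2ccc(CNC(=O)OCc3cccnc3)cc2)c1N1CCCC1` gives > 100000 nM

For compound 3 the entry > 100000 nM is a limit of the assay and not a number. That leaves two numerical values in this assay to compare. For the measured compounds named here, compound 1 stands at 65300 nM and has compound 2 as its only numerical neighbour, with a 1.5-fold lower number from compound 1 to compound 2 (0.16 log units; within the scatter) separating them. The two therefore cannot be ordered.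

The next step leads to compound 4 `O=C(NCc1ccc(NC(=O)c2cc(C(F)(F)F)ccc2N2CCCC2)cc1)OCc1cccnc1` and is trifluoromethyl in place of methyl on an aromatic carbon. Going by the values given here, the one measured step bearing on this change is also a replacement of methyl on an aromatic carbon, fluoro in this case, and it gave a 1.5-fold lower number from compound 1 to compound 2 (0.16 log units; within the scatter) as its whole effect. On that single step, no shift beyond the scatter is expected in this assay in either direction. The estimated change is a 1.3-fold lower number from compound 1 to compound 4 (0.12 log units; within the scatter) and no more than that. Compound 4 is estimated at 50000 nM with an expected range from 20000 nM to 95000 nM as its upper end.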

Compound 4, half-maximal inhibitory concentration: > 100000 nM
Compound 4 gave a limit, no number; the forecaster's own chance of this, stated with the estimate: 20%; middle value at least 2.0-fold (0.30 log units) from the limit.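

In this assay, compound 4 carries a limit of the assay and not a number: the limit of > 100000 nM in this assay, at which 2 of the 4 values shown sit. Trifluoromethyl in place of fluoro gives an at least 2.2-fold higher number from compound 2 to compound 4 (0.34 log units; beyond the scatter), so this carbon, para to a pyrrolidin-1-yl group, does respond to the group it carries, which the step between compound 1 and compound 2 did not show. Trifluoromethyl in place of methyl gives an at least 1.5-fold higher number from compound 1 to compound 4 (0.18 log units; that floor lies within the scatter), and that floor alone does not order the pair.

Going by these compounds, how far compound 4 lies beyond its limit remains open, so the full size of both steps is unknown. Also open, on these data alone, is whether a methoxy group, an amine or a carboxylic acid on this carbon would give a lower number than compound 2 shows at 44800 nM.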